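Working notes: from compound 3 to compound 4

The compounds below may be only part of what the source reports. "The series", "measured", "known", "first", "only" and "open" are said of these compounds alone.

Measured so far in a functional assay on SF-268 cells (Homo sapiens) for cytotoxicity, read by sulforhodamine B assay, with a stated time of 48 h; on this read-out lower numbers stand for stronger inhibition of growth and higher numbers for weaker inhibition of growth:
compound 1 `CC1=C(C(=O)Nc2ccc(Cl)c(Cl)c2)C(c2cccc(O)c2)NC(=S)N1` gives 15800 nM
compound 2 `CC1=C(C(=O)Nc2ccc(F)c(Cl)c2)C(c2cccc(Cl)c2)NC(=S)N1` gives 10000 nM
compound 3 `CC1=C(C(=O)Nc2ccc(F)c(Cl)c2)C(c2cccc(Oc3ccccc3)c2)NC(=S)N1` gives 8910 nM

On these three numbers compound 3 cannot be set apart from the others: the step of a 1.1-fold lower number from compound 2 to compound 3 (0.05 log units; within the scatter) lies within the scatter, and the gap between compound 1 and compound 3 also lies within the scatter. Among the measured compounds shown here, the only single-point change measured so far, phenoxy for chloro on the second aromatic ring, thus left this assay unmoved beyond its noise.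

Compound 4 `CC1=C(C(=O)Nc2ccc(Cl)c(Cl)c2)C(c2cccc(Oc3ccccc3)c2)NC(=S)N1` is the next single-point change from compound 3: chloro in place of fluoro on an aromatic carbon. For the measured compounds named here, no measured pair isolates this fluoro-to-chloro swap. Going by the values given here, compound 1 carries the same (3,4-dichlorophenyl)amino group as compound 4 but differs from compound 3 in two places at once, so its value shows only that a compound with that group sits within the scatter of compound 3. Among the compounds with values here, with no step bearing directly on the change, the expectation for compound 4 is a step of a 1.0-fold higher number from compound 3 to compound 4 (0.00 log units; within the scatter), that is, none beyond the scatter. Compound 4 is therefore estimated at 9000 nM, with a range from 4000 nM to 20000 nM.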

Compound 4, concentration for 50% growth inhibition: 6170 nM
For compound 4 the middle estimate is 1.5-fold (0.16 log units) above the measured one; measured number inside the range.
By their numbers in this assay, from the lowest: compounds 4, 3, 2 and 1 (each within the scatter of the next, the first and the last beyond it).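

In this assay, the exchange of fluoro for chloro on the aromatic carbon ortho to a chloro group and para to a large group can now be read on its own: a 1.4-fold lower number from compound 3 to compound 4 (0.16 log units; within the scatter) places 3-chloro-4-fluorophenyl and 3,4-dichlorophenyl within the scatter of each other, at least with phenoxy on the second aromatic ring. Among the compounds shown here, the same compound also gives the first single-point step beyond the scatter, though a modest one, a 2.6-fold lower number from compound 1 to compound 4 (0.41 log units; beyond the scatter), so the oxygen on the second aromatic ring responds to phenyl in place of its hydrogen, while a 1.1-fold lower number from compound 2 to compound 3 (0.05 log units; within the scatter) shows that phenoxy and chloro on that ring cannot be told apart. Nothing at hand explains either step.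

As far as these compounds go, whether chloro and fluoro remain interchangeable with hydroxy or chloro on the second aromatic ring stays open, as does the effect of bromo, methyl or trifluoromethyl at the same aromatic carbon. From the compounds shown here alone, on the oxygen, it also stays open how a methyl, a longer chain, or a phenyl carrying an amine or a carboxylic acid would compare with the plain phenyl.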